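Removing one 3-methylbut-2-en-1-yl group from compound 1

A few compounds are considered here, and "the series" means these few. Any claim that something is new, unique, unknown or untested is made for them only; others in the source may bear on it.

Compound 1 `CC(C)=CCOc1c(CC=C(C)C)c(O)nc2ccccc12` gives 71200 nM 
Compound 2 `CC(C)CCOc1c(CCC(C)C)c(O)nc2ccccc12` gives 160000 nM 

All values come from an ADME assay on CCRF-CEM cells (Homo sapiens) for cytotoxicity, read by MTT assay, with a stated time of 72 h (a higher number here means that more compound is tolerated, a lower number that less compound is tolerated), and compound 1 stands lowest of the two, with compound 2 higher by more than the usual scatter. Compound 3 `CC(C)=CCOc1cc(O)nc2ccccc12` differs from compound 1 by hydrogen in place of 3-methylbut-2-en-1-yl on an aromatic carbon with hydrogen in place of 3-methylbut-2-en-1-yl on an aromatic carbon. For the measured compounds named here, no measured pair shows this change, so only a moderate upward step in this assay is expected, towards the level of compound 2 at 160000 nM as the nearest reference. The expected size is a 2.0-fold higher number from compound 1 to compound 3 (0.29 log units; within the scatter) and it remains an estimate. For compound 3 the estimated value is 140000 nM within an expected range of 60000 nM to 350000 nM on present data.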

Compound 3, half-maximal cytotoxic concentration: 77400 nM
For compound 3 the middle estimate is 1.8-fold (0.26 log units) above the measured one, and the stated range covers the measured number.
By their numbers in this assay, from the lowest: compounds 1 and 3 (each within the scatter of the next); then compound 2.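

In this assay, hydrogen in place of 3-methylbut-2-en-1-yl on the aromatic carbon ortho to the hydroxy group gives a 1.1-fold higher number from compound 1 to compound 3 (0.04 log units; within the scatter). This first single-place comparison in the series shows that the 3-methylbut-2-en-1-yl group can be absent from this position without a change beyond the scatter. Nothing available explains this result. Still open, from the compounds shown here alone, is whether an amine, a carboxylic acid or a longer chain at this position would also leave the number unchanged. Going by these compounds, the effect of replacing the (3-methylbut-2-en-1-yl)oxy group, present in both compound 1 and compound 3, also remains open.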